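Bromo to Trifluoromethyl: A Step Expected Within Scatter

This account rests on a few compounds, and the source may have more. Where it says the series, first, only, none or still open, it means among the compounds named here.

Compound 1 `NC(=O)c1c(NC(=O)c2ccccc2Br)sc2c1CCN(C(=S)Nc1ccccc1Cl)C2` and compound 2 `NC(=O)c1c(NC(=O)c2ccccc2Br)sc2c1CCN(C(=S)Nc1ccccc1Br)C2` share the same core and differ in one place only. In a functional assay on MKN-74 cells (Homo sapiens) for antiproliferative activity, with a stated time of 24 h (on this read-out higher numbers stand for weaker inhibition and lower numbers for stronger inhibition), compound 1 gives 12900 nM, and compound 2 gives 13700 nM. The step of a 1.1-fold higher number from compound 1 to compound 2 (0.03 log units; within the scatter) falls within the scatter, so the two numbers cannot be told apart; compound 2 holds the higher of the two numbers, but by a margin this assay does not resolve. Compound 3 `NC(=O)c1c(NC(=O)c2ccccc2Br)sc2c1CCN(C(=S)Nc1ccccc1C(F)(F)F)C2` introduces a new change: trifluoromethyl in place of bromo on an aromatic carbon. Among the compounds with values here, no measured step involves a trifluoromethyl group, so the only guide is a 1.1-fold higher number from compound 1 to compound 2 (0.03 log units; within the scatter), which shows that replacing one group at this position by another left this assay unchanged. Compound 3 is therefore expected to give 13000 nM, with a range from 5000 nM to 35000 nM. The expected step of a 1.1-fold lower number from compound 2 to compound 3 (0.02 log units; within the scatter) is thus estimated to be nothing beyond the scatter.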

Compound 3, half-maximal inhibitory concentration: 24300 nM
Compound 3: middle estimate off by 1.9-fold (0.27 log units), on the low side; measured number inside the range.
By their numbers in this assay, from the lowest: compounds 1, 2 and 3 (each within the scatter of the next).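

In this assay the change from bromo, a single heavy atom, to trifluoromethyl, with four heavy atoms, gives a step that stays within the scatter (a 1.8-fold higher number from compound 2 to compound 3 (0.25 log units; within the scatter)), and the same holds for the change from chloro (a 1.9-fold higher number from compound 1 to compound 3 (0.28 log units; within the scatter)). The tolerance seen so far at this aromatic carbon therefore extends beyond the swap of chloro for bromo to a group with more heavy atoms, since compounds 1, 2 and 3 cannot be told apart here. Nothing given here accounts for these numbers.

All three groups carry no hydrogen-bond donors or acceptors and no net charge, so the compounds shown leave open what an amine or a carboxylic acid at this place would do. Whether such a group would move the number beyond the scatter remains an open question.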